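One More Carbon on the Chain of Compound 3

This account rests on a few compounds, and the source may have more. Where it says the series, first, only, none or still open, it means among the compounds named here.

Measured in a functional assay on A549 cells (Homo sapiens) for antiproliferative activity, read by MTT assay, with a stated time of 72 h (on this read-out higher numbers stand for weaker inhibition and lower numbers for stronger inhibition), so far:
- compound 1 `CCC/C=C/C(=O)Nc1cc2c(N3CCCc4ccccc43)ncnc2cc1OC` gives 1800 nM
- compound 2 `C/C=C/C(=O)Nc1cc2c(N3CCCc4ccccc43)ncnc2cc1O[C@@H]1CCOC1` gives 10800 nM
- compound 3 `CC/C=C/C(=O)Nc1cc2c(N3CCCc4ccccc43)ncnc2cc1O[C@@H]1CCOC1` gives 14100 nM

Compound 3 stands level with compound 2 within the scatter, and both numbers lie well above that of compound 1. The next compound to be tested is compound 4 `CCC/C=C/C(=O)Nc1cc2c(N3CCCc4ccccc43)ncnc2cc1O[C@@H]1CCOC1`, and the change leading to it is methyl in place of hydrogen on a saturated chain carbon, two bonds along the chain from a double-bonded chain carbon. In words, a methyl replaces a hydrogen on a saturated chain carbon, two bonds along the chain from a double-bonded chain carbon, turning but-1-en-1-yl into pent-1-en-1-yl.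

Going by the values given here, the closest precedent is the same kind of lengthening, one carbon earlier in the chain, and it gave a 1.3-fold higher number from compound 2 to compound 3 (0.12 log units; within the scatter). Compound 1 already carries the pent-1-en-1-yl chain but differs elsewhere, so it does not isolate this change. In this assay, no shift beyond the scatter is therefore expected, and no direction can be favoured. The expected result is a 1.1-fold lower number from compound 3 to compound 4 (0.04 log units; within the scatter). Compound 4 is estimated at 13000 nM, with an expected range of 6000 nM to 28000 nM.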

Compound 4, half-maximal inhibitory concentration: 7320 nM
Compound 4: the middle estimate sits 1.8-fold (0.25 log units) above what was measured, and the stated range covers the measured number.
By their numbers in this assay, from the lowest: compound 1; then compounds 4, 2 and 3 (each within the scatter of the next).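

In this assay, going from but-1-en-1-yl to pent-1-en-1-yl gives a 1.9-fold lower number from compound 3 to compound 4 (0.28 log units; within the scatter) and the longer step from the shorter chain of compound 2 gives a 1.5-fold lower number from compound 2 to compound 4 (0.17 log units; within the scatter) so compounds 2, 3 and 4 all stay within the scatter of one another. The swap on the oxygen on an aromatic ring can now be read alone, with the pent-1-en-1-yl chain held fixed: oxolan-3-yl in place of methyl gives a 4.1-fold higher number from compound 1 to compound 4 (0.61 log units; beyond the scatter). Compound 1 differed from compounds 2 and 3 in two places. No measurement here offers an explanation for either result.

Going by these compounds, whether a longer chain such as hex-1-en-1-yl, or an amine at the end of the chain, would stay within the same scatter remains open. So does the effect of an ethyl group on that oxygen.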